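This account rests on a few compounds, and the source may have more. Where it says the series, first, only, none or still open, it means among the compounds named here.

Compound 1 `CCSCCC12CCC(c3nnc(-c4ccccc4C(F)(F)F)n3C)(CC1)CC2` gives in an assay on CHO-K1 cells for inhibition of 11-beta-hydroxysteroid dehydrogenase type 2 (Homo sapiens), read by scintillation proximity assay (a lower number here means a stronger inhibitor, a higher number a weaker inhibitor), a value that is a limit of the assay, > 4000 nM. Compound 2 `Cn1c(-c2ccccc2C(F)(F)F)nnc1C12CCC(CCS(=O)(=O)C(C)(C)C)(CC1)CC2` likewise sits at a limit in this assay, > 4000 nM. Compound 3 `CCS(=O)(=O)CCC12CCC(c3nnc(-c4ccccc4Br)n3C)(CC1)CC2` returns a limit too, > 4000 nM. Going by the values given here, the single step measured between two of these, a step that the two limits leave unreadable from compound 1 to compound 2, cannot be read because of the limit of > 4000 nM in this assay, at which 3 of the 3 values shown sit. Compound 2 therefore stands only at a limit, with no number of its own. Compound 4 `Cn1c(-c2ccccc2C(F)(F)F)nnc1C12CCC(CCCC(C)(F)F)(CC1)CC2` differs from compound 2 by 2,2-difluoropropyl in place of (tert-butyl)sulfonyl on a saturated chain carbon, two bonds along the chain from a saturated ring carbon. No readable measured step bears on this change, so the direction is open. Compound 4 is expected to move by about a step that the limit leaves unreadable from compound 2 to compound 4 in this assay. Compound 4 is estimated at 6000 nM, between 1500 nM and 30000 nM.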

Compound 4, half-maximal inhibitory concentration: > 4000 nM
Compound 4: only a limit was reported; the forecaster's own chance of this, stated with the estimate: 70%; the middle value does not contradict the limit.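

Compound 4 gives > 4000 nM in this assay, which is a limit of the assay, so its steps from compound 1 and compound 2 cannot be read: the limit of > 4000 nM in this assay, at which 4 of the 4 values shown sit.

The compounds shown leave open how any of these chain groups affects inhibition, since none has a numerical value.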